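The source may report more compounds than this note shows. Statements on the series, on what has been measured and on what is new or still open speak of the compounds shown alone.

Measured compounds:
compound 1 `CC1=C/C(=C\C(C)C)C(=O)C(C)(O)C12CC2`, 300 nM
compound 2 `C/C=C1\C=C(C)C2(CC2)C(C)(O)C1=O`, 110 nM
compound 3 `CC1=C/C(=C\Cl)C(=O)C(C)(O)C12CC2`, 300 nM

In a functional assay on MDA-MB-231 cells (Homo sapiens) for antiproliferative activity (on this read-out higher numbers stand for weaker inhibition and lower numbers for stronger inhibition), compound 3 gives 300 nM, level with compound 1 and together with it the highest of the three numbers; compound 2, with 110 nM, is the only one that parts from them beyond the scatter, as a 2.7-fold higher number from compound 2 to compound 3 (0.44 log units; beyond the scatter) shows. Compound 4 `CC1=C/C(=C\C#CCCO)C(=O)C(C)(O)C12CC2` differs from compound 3 in one place: 4-hydroxybut-1-yn-1-yl in place of chloro on a double-bonded chain carbon bound to a double-bonded ring carbon. Within the data shown here, two measured steps bear on this position. Going no change at the digits printed from compound 1 to compound 3 (within the scatter), a larger branched group and a single chlorine gave the same number, and a 2.7-fold higher number from compound 2 to compound 3 (0.44 log units; beyond the scatter), so only the smallest group stood apart. Among the measured compounds shown here, the hydroxybutynyl chain is larger than any group measured at this carbon and carries a donor and an acceptor, for which no measured step gives guidance. He therefore expects no step beyond the scatter, that is no change at the digits printed from compound 3 to compound 4 (within the scatter), and estimates compound 4 at 300 nM in this assay, with a range from 100 nM to 1000 nM.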

Compound 4, half-maximal inhibitory concentration: 2000 nM
Beside the measured number, compound 4's estimate is 6.7-fold (0.82 log units) below it, outside the stated range (above it).
By their numbers in this assay, from the lowest: compound 2; then compounds 1 and 3 (each within the scatter of the next); then compound 4.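

In this assay, chloro and isopropyl on this carbon had given the same number, and only methyl had stood apart, on the lower side. The 4-hydroxybut-1-yn-1-yl chain now shows that this position can also move the number upward, with a 6.7-fold higher number from compound 3 to compound 4 (0.82 log units; beyond the scatter) and, against the isopropyl group, a 6.7-fold higher number from compound 1 to compound 4 (0.82 log units; beyond the scatter), while the widest gap at this position, an 18-fold higher number from compound 2 to compound 4 (1.26 log units; beyond the scatter), is large. Nothing in the data at hand accounts for this rise.

The compounds shown leave open whether the triple bond, the terminal hydroxyl or the chain length carries the change; a plain butynyl chain or a saturated 4-hydroxybutyl chain would separate these. From the compounds shown here alone, how an amine or a carboxylic acid at the end of such a chain would read in this assay also remains open.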